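A few compounds are considered here, and "the series" means these few. Any claim that something is new, unique, unknown or untested is made for them only; others in the source may bear on it.

Working notes on the series.

Compound 2 `COc1ccc2[nH]c(C(=O)N3CC(=O)N(Cc4ccccc4)[C@@H](CN4CC5CCCCC5C4)C3)cc2c1` gives 8200 nM in an ADME assay on Vero cells (Chlorocebus sabaeus) for cytotoxicity, with a stated time of 7 days (a higher number here means that more compound is tolerated, a lower number that less compound is tolerated), the highest of the two numbers in hand. Going by the values given here, compound 1 `COc1ccc2[nH]c(C(=O)N3CC(=O)N(Cc4ccccc4)[C@@H](N4[C@H](C)CCC[C@@H]4C)C3)cc2c1` gives 1400 nM in this assay, and the only measured step, a 5.9-fold higher number from compound 1 to compound 2 (0.77 log units; beyond the scatter), exchanges one saturated amine for another on the shared core.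

Compound 3 `COc1ccc2[nH]c(C(=O)N3CC(=O)N(Cc4ccccc4)[C@@H](CN4CC5CCCC5C4)C3)cc2c1` differs from compound 2 by a group of 8 heavy atoms (7 carbon, 1 nitrogen; one five-membered non-aromatic ring of carbon only, one five-membered non-aromatic ring with 1 hetero atom) in place of a group of 9 heavy atoms (8 carbon, 1 nitrogen; one five-membered non-aromatic ring with 1 hetero atom, one six-membered non-aromatic ring of carbon only), on a saturated chain carbon bound to a saturated ring carbon. This is a smaller change than the measured step: the amine stays bicyclic and its attachment on a saturated chain carbon bound to a saturated ring carbon is kept, only one carbocycle shrinks by one ring member. The step from compound 1 to compound 2 bears on it only loosely, since that step also moved the amine nitrogen onto a chain. Among the compounds with values here, no step in this assay beyond the scatter is therefore expected; compound 3 is expected to sit near compound 2, with a 1.2-fold lower number from compound 2 to compound 3 (0.07 log units; within the scatter). The estimate for compound 3 is 7000 nM, within a range of 3000 nM to 16000 nM.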

Compound 3, half-maximal cytotoxic concentration: 10600 nM
Estimate against measurement, compound 3: 1.5-fold (0.18 log units) below; low and high end bracket the measured number.
By their numbers in this assay, from the lowest: compound 1; then compounds 2 and 3 (each within the scatter of the next).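

In this assay the exchange of the six-membered carbocycle for the five-membered one, on a saturated chain carbon bound to a saturated ring carbon, gives a 1.3-fold higher number from compound 2 to compound 3 (0.11 log units; within the scatter) and so does not separate the two bicyclic amines at this position. With a 7.6-fold higher number from compound 1 to compound 3 (0.88 log units; beyond the scatter) alongside a 5.9-fold higher number from compound 1 to compound 2 (0.77 log units; beyond the scatter), both bicyclic amines now stand beyond the scatter from compound 1, so that difference no longer rests on a single amine. No supporting measurement bears on the reason for these numbers.

The compounds shown do not separate the ring system of the amine from its attachment through a chain carbon, which a dimethylpiperidine on the same chain carbon would address. Also open, going by these compounds, is whether a morpholine or an acyclic diethylamine at this place would stay with compound 2 and compound 3 or fall nearer compound 1.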